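The source may report more compounds than this note shows. Statements on the series, on what has been measured and on what is new or still open speak of the compounds shown alone.

Working notes on the series. Compound 1 `N#CC1=C(N)N(c2ccc(S(N)(=O)=O)cc2)C2=C(CCCC2)C1/C=C/c1ccccc1` and compound 2 `N#CC1=C(N)N(c2ccc(S(N)(=O)=O)cc2)C2=C(CCCC2)C1c1ccc(Cl)cc1Cl` share one core and differ only at the saturated ring carbon. In a functional assay on Ehrlich cells (Mus musculus) for cytotoxicity, read by trypan blue exclusion, with a stated time of 2 h, tested at 100 ug/mL (on this read-out higher numbers stand for a stronger effect at the one concentration tested and lower numbers for a weaker effect), compound 1 gives 70%. In the same read-out compound 2 gives 70%. The step of no change at the digits printed from compound 1 to compound 2 (within the scatter) lies within the scatter, so compound 2 stands level with compound 1 at the digits shown; no order between the two can be claimed.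

Compound 3 `N#CC1=C(N)N(c2ccc(S(N)(=O)=O)cc2)C2=C(CCCC2)C1c1cccs1` is not yet measured. Its change from compound 2 is thiophen-2-yl in place of 2,4-dichlorophenyl on a saturated ring carbon. For the measured compounds named here, the only measured step bearing on this position is no change at the digits printed from compound 1 to compound 2 (within the scatter), in which a different group on the same saturated ring carbon left the read-out unmoved beyond the scatter. Nothing is known here about thiophen-2-yl on its own. The expected step is therefore none beyond the scatter, written as no change at the digits printed from compound 2 to compound 3 (within the scatter). Compound 3 is estimated at 70%, with a range from 55% to 85%.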

Compound 3, a percentage reported as activity, at one concentration (the size of the read-out at that concentration, not a potency): 20%
For compound 3 the middle estimate is 50 percentage points above the measured one, and the stated range ends above it.
By their numbers in this assay, from the lowest: compound 3; then compounds 1 and 2 (each within the scatter of the next).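

On the saturated ring carbon the substituent does matter in this assay, which the level pair of compounds 1 and 2 could not show. Thiophen-2-yl in place of 2,4-dichlorophenyl gives a number 50 percentage points lower from compound 2 to compound 3 (beyond the scatter), and thiophen-2-yl in place of 2-phenylethenyl gives a number 50 percentage points lower from compound 1 to compound 3 (beyond the scatter), so two quite different groups stand level while this one stands apart. No data here bear on the origin of this fall.

Still open, as far as these compounds go, is whether the fall goes with the sulfur-containing five-membered ring or with the absence of the groups it replaces; a plain phenyl, a furan-2-yl or a thiophen-3-yl on the same carbon would separate these. The one concentration tested also leaves potency itself open.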